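Methoxy removal across two fused cores

A few compounds are considered here, and "the series" means these few. Any claim that something is new, unique, unknown or untested is made for them only; others in the source may bear on it.

Compound 1 `COc1cc2ncnc(Oc3ccc(F)cc3F)c2cc1OC` gives 1200 nM in an assay on HEK293-TREx cells for antagonist activity at transient receptor potential cation channel subfamily A member 1 (Homo sapiens), read by fluorescence and calcium flux, with a stated time of 72 h; on this read-out lower numbers stand for stronger inhibition and higher numbers for weaker inhibition. Among the compounds with values here, compound 2 `COc1ccc2c(Oc3ccc(F)cc3F)ncnc2c1` gives 3000 nM in this assay, and the step of a 2.5-fold higher number from compound 1 to compound 2 (0.40 log units; beyond the scatter) is the only measured instance of this change: hydrogen in place of methoxy on an aromatic carbon. Compound 3 `COc1ccc2c(Oc3ccc(F)cc3F)nccc2c1` gives 1300 nM in this assay; compound 3 and compound 1 sit within the scatter of each other, and the difference between the core of compound 3 and that of compound 1 is not broken down here. Compound 4 `Fc1ccc(Oc2nccc3ccccc23)c(F)c1` is not yet measured. It differs from compound 3 thus: hydrogen in place of methoxy on an aromatic carbon. This is the same kind of change as that from compound 1 to compound 2, but not the same: in compound 1 the methoxy that leaves is ortho to a methoxy group, whereas the place in compound 3 carries no such group, the rest of its description being identical. Resting on the measured step of a 2.5-fold higher number from compound 1 to compound 2 (0.40 log units; beyond the scatter), the expected step is a 2.3-fold higher number from compound 3 to compound 4 (0.36 log units; beyond the scatter). Within the data shown here, only one measured step supports this; the bounds are kept wide. Compound 4 is expected to give about 3000 nM, plausibly between 1400 nM and 6500 nM.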

Compound 4, half-maximal inhibitory concentration: 3100 nM
For compound 4 the middle estimate is 1.0-fold (0.01 log units) below the measured one, and the stated range covers the measured number.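

In this assay, hydrogen in place of methoxy gives a 2.4-fold higher number from compound 3 to compound 4 (0.38 log units; beyond the scatter) on the second core, and the size of the step matches that seen on the first core: the same change on two cores in this assay, a 2.5-fold higher number (0.40 log units; beyond the scatter) from compound 1 to compound 2 and a 2.4-fold higher number (0.38 log units; beyond the scatter) from compound 3 to compound 4, 1.0-fold (0.02 log units) apart, within the scatter of two such steps.

Within this pair of cores the change therefore carries over with its size intact, even though compound 2 keeps a methoxy and compound 4 keeps none. Two steps in one assay show agreement only; they do not show that the step would hold on any other core, and they give no reason for the loss of inhibition or for the agreement.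

The compounds shown leave open what a group other than methoxy or hydrogen would give on the same aromatic carbon, for example an amine, a hydroxyl or a longer chain such as ethoxy. They also leave open whether the step keeps its size when the fluorinated ring, the same in all four compounds, carries other groups.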